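Changing the amide ring: from compound 2 to compound 4

The compounds below may be only part of what the source reports. "The series", "measured", "known", "first", "only" and "open" are said of these compounds alone.

Of the compounds shown here, three built on one shared core have been tested in a functional assay on MCF7 cells (Homo sapiens) for inhibition, read by MTT assay, with a stated time of 48 h; on this read-out lower numbers stand for stronger inhibition and higher numbers for weaker inhibition. Compound 1 `COc1ccc(/C=C/c2cc(OC)cc(OC)c2/C=C/C(=O)N2CCCCC2C)cc1` gives 4350 nM in this assay. Compound 2 `COc1ccc(/C=C/c2cc(OC)cc(OC)c2/C=C/C(=O)N2CCC(Cl)CC2)cc1` gives 4950 nM, and compound 3 `COc1ccc(/C=C/c2cc(OC)cc(OC)c2/C=C/C(=O)N2CCCC2)cc1` gives 4200 nM. Of these three numbers compound 2 shows the highest, yet the step of a 1.1-fold higher number from compound 1 to compound 2 (0.06 log units; within the scatter) and the step of a 1.2-fold lower number from compound 2 to compound 3 (0.07 log units; within the scatter) are both within the scatter, so the three compounds cannot be told apart on this read-out.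

Compound 4 `COc1ccc(/C=C/c2cc(OC)cc(OC)c2/C=C/C(=O)N2CCCC(C)C2)cc1` has not yet been measured. It differs from compound 2 in one place: 3-methylpiperidin-1-yl in place of 4-chloropiperidin-1-yl on a carbonyl carbon. For the measured compounds named here, every measured step so far also exchanges the ring on the carbonyl carbon: a 1.1-fold higher number from compound 1 to compound 2 (0.06 log units; within the scatter), a 1.0-fold lower number from compound 1 to compound 3 (0.02 log units; within the scatter) and a 1.2-fold lower number from compound 2 to compound 3 (0.07 log units; within the scatter). None of them moves the number beyond the scatter, which gives no sign that swapping rings at this position shifts the result. No measured step involves a 3-methylpiperidin-1-yl group, so the expectation rests only on the three steps shown.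

The step from compound 2 to compound 4 is therefore expected to be a 1.1-fold lower number from compound 2 to compound 4 (0.03 log units; within the scatter), nothing beyond the scatter. Compound 4 is estimated to give 4600 nM in this assay, with a range from 2300 nM to 9200 nM.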

Compound 4, half-maximal inhibitory concentration: 11900 nM
Compound 4: middle estimate off by 2.6-fold (0.41 log units), on the low side; measured number above the stated range.
By their numbers in this assay, from the lowest: compounds 3, 1 and 2 (each within the scatter of the next); then compound 4.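

The ring on the carbonyl carbon can move the number after all. In this assay the 3-methylpiperidin-1-yl group stands apart from the other three rings, with a 2.4-fold higher number from compound 2 to compound 4 (0.38 log units; beyond the scatter) and a 2.8-fold higher number from compound 3 to compound 4 (0.45 log units; beyond the scatter) and also a 2.7-fold higher number from compound 1 to compound 4 (0.44 log units; beyond the scatter) as steps that are modest in size yet all beyond the scatter. Neither the methyl group alone nor the count of heavy atoms sorts these results, since compound 1 also carries a methyl on a piperidine ring and stays with compound 2 and compound 3, while 4-chloropiperidin-1-yl and 3-methylpiperidin-1-yl have the same count of heavy atoms, and nothing measured here explains why this one group differs.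

As far as these compounds go, how an unsubstituted piperidin-1-yl group or a 4-methylpiperidin-1-yl group would compare remains open, so it is unclear whether the higher number belongs to the methyl at the 3-position specifically. Also open, from the compounds shown here alone, is where a ring with a second hetero atom, such as morpholin-4-yl, or an open-chain diethylamino group on the same carbonyl carbon would fall.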